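Series notes: methoxy to hydroxy from compound 3

The compounds below may be only part of what the source reports. "The series", "measured", "known", "first", "only" and "open" are said of these compounds alone.

In a functional assay on RAW264.7 cells (Mus musculus) for inhibition, read by Griess assay, with stated times of 2 h and 18 h (on this read-out lower numbers stand for stronger inhibition and higher numbers for weaker inhibition), compound 1 `CCC(=O)[C@H]1O[C@](O)(CCC2=CC(OC)OC2=O)[C@@]2(C)CCCC(C)(C)[C@H]12` gives 15700 nM and compound 2 `CCC(=O)[C@H]1O[C@@](CCC2=CCOC2=O)(OC)[C@@]2(C)CCCC(C)(C)[C@H]12` gives 21900 nM. These two values lie within the usual scatter of each other. Compound 3 `CCC(=O)[C@H]1O[C@@](CCc2ccoc2)(OC)[C@@]2(C)CCCC(C)(C)[C@H]12` gives only a limit of the assay, > 50000 nM. It therefore has a bound in this assay, not a number.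

Compound 4 `CCC(=O)[C@H]1O[C@](O)(CCc2ccoc2)[C@@]2(C)CCCC(C)(C)[C@H]12` is still unmeasured. It differs from compound 3 by hydrogen in place of methyl on an oxygen on a saturated carbon, or methoxy to hydroxy.

Among the measured compounds shown here, no measured step covers this change directly. For the measured compounds named here, the one measured step, an at least 2.2-fold higher number from compound 2 to compound 3 (0.35 log units; beyond the scatter), concerns a different group, and it is open-ended. The closest guide is the pair of compound 1 and compound 2, which carry hydroxy and methoxy respectively at that carbon but also differ elsewhere, and which show no gap beyond the scatter.

In this assay only a small step towards a lower number is therefore expected, possibly none beyond the scatter. The estimated step is an at least 1.2-fold lower number from compound 3 to compound 4 (0.09 log units; that floor lies within the scatter). The expected value for compound 4 is 40000 nM, with an estimated range of 16000 nM to 90000 nM.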

Compound 4, half-maximal inhibitory concentration: > 50000 nM
Compound 4 ended at the assay's limit; the forecaster's own chance of this, stated with the estimate: 50%; middle value at least 1.2-fold (0.09 log units) away from the limit.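

In this assay compound 4 stands at a limit of the assay (> 50000 nM), so hydroxy in place of methoxy on this saturated carbon does not bring the series with the five-membered aromatic ring onto a measurable number. The step from compound 3 to compound 4 cannot be read because both compounds sit at that limit: the limit of > 50000 nM in this assay, at which 2 of the 4 values shown sit. The chain group now has a second reading, since an at least 2.2-fold higher number from compound 2 to compound 3 (0.35 log units; beyond the scatter) came from compounds with methoxy on that carbon, while an at least 3.1-fold higher number from compound 1 to compound 4 (0.50 log units; beyond the scatter) goes the same way with hydroxy there.

Among the compounds shown here, whether methoxy to hydroxy changes anything at all stays open, as the only pair that could show it sits at the limit, and compound 1 and compound 2 also differ elsewhere. Also open, on these data alone, is how an amine or a carboxylic acid would read in place of the ring on the chain, and whether a longer chain would move the number in either direction.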